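Lengthening benzylsulfanyl to (3-phenylpropyl)sulfanyl on a shared core

The compounds below may be only part of what the source reports. "The series", "measured", "known", "first", "only" and "open" are said of these compounds alone.

Compound 1 `Cc1cc(N2CC[C@@H](C)[C@@H](N(C)c3ncnc4[nH]ccc34)C2)n2nc(SCc3ccccc3)nc2n1` gives 13900 nM in a functional assay on HGC-27 cells (Homo sapiens) for inhibition, read by MTT assay, with a stated time of 72 h (a higher number here means a weaker inhibitor, a lower number a stronger inhibitor), the second highest of the three numbers measured; compound 3 `Cc1cc(N2CC[C@@H](C)[C@@H](N(C)c3ncnc4[nH]ccc34)C2)n2nc(SCC3CCCCC3)nc2n1` stands nearest with 11500 nM, and compound 2 `Cc1cc(N2CC[C@@H](C)[C@@H](N(C)c3ncnc4[nH]ccc34)C2)n2nc(SCc3ccccc3Br)nc2n1` furthest with 21300 nM. The change to compound 4 `Cc1cc(N2CC[C@@H](C)[C@@H](N(C)c3ncnc4[nH]ccc34)C2)n2nc(SCCCc3ccccc3)nc2n1` is phenethyl in place of phenyl on a saturated chain carbon bound to a sulfur. All three measured steps sit at the same place, on the saturated chain carbon bound to a sulfur, and every one of them lies within the scatter: a 1.5-fold higher number from compound 1 to compound 2 (0.19 log units; within the scatter), a 1.2-fold lower number from compound 1 to compound 3 (0.08 log units; within the scatter) and a 1.9-fold lower number from compound 2 to compound 3 (0.27 log units; within the scatter). Going from benzyl to 3-phenylpropyl is therefore expected to leave the number within the scatter of compound 1, with no step in either direction beyond it. Compound 4 is estimated at 12500 nM, between 5000 nM and 32000 nM. This estimate means a step of a 1.1-fold lower number from compound 1 to compound 4 (0.05 log units; within the scatter).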

Compound 4, half-maximal inhibitory concentration: > 100000 nM
Compound 4: no number, only a limit; the forecaster's own chance of this, stated with the estimate: 10%; middle value at least 8.0-fold (0.90 log units) away from the limit.
By their numbers in this assay, from the lowest: compounds 3, 1 and 2 (each within the scatter of the next). At a limit, above all of these: compound 4.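

At this position, on a saturated chain carbon bound to a sulfur, the earlier swaps of the ring left the number in this assay within the scatter, but lengthening benzyl to 3-phenylpropyl does not: an at least 7.1-fold higher number from compound 1 to compound 4 (0.85 log units; beyond the scatter), an at least 8.6-fold higher number from compound 3 to compound 4 (0.93 log units; beyond the scatter) and an at least 4.6-fold higher number from compound 2 to compound 4 (0.67 log units; beyond the scatter). The chain length at this place therefore matters among these compounds in a way the ring swaps did not show. The reading for compound 4 is a limit, so these steps give only a lower bound: the limit of > 100000 nM in this assay, at which 1 of the 4 values shown sits. The compounds shown leave open how a (2-phenylethyl)sulfanyl group would read, and whether an amine on the end of the longer chain would restore a measurable number.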